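Working notes: from compound 3 to compound 4

A few compounds are considered here, and "the series" means these few. Any claim that something is new, unique, unknown or untested is made for them only; others in the source may bear on it.

Measured in an ADME assay on NCM460 cells (Homo sapiens) for cytotoxicity, read by CCK-8 assay, with a stated time of 48 h; on this read-out higher numbers stand for weaker inhibition and lower numbers for stronger inhibition
- compound 1 (`COc1ccc(/C=C\c2cc(OC)c(OC)c(OC)c2)cc1OCc1ccc(CN2C[C@H](O)C[C@@H]2C(=O)O)cc1`) gives > 50000 nM
- compound 2 (`COc1ccc(/C=C\c2cc(OC)c(OC)c(OC)c2)cc1OCc1ccc(CN2CCCCC2C(=O)O)cc1`) gives > 50000 nM
- compound 3 (`COc1ccc(/C=C\c2cc(OC)c(OC)c(OC)c2)cc1OCc1ccc(CN[C@H](C(=O)O)[C@H](C)O)cc1`) gives > 50000 nM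

All three entries are limits of the assay and not numbers (the limit of > 50000 nM in this assay, at which 3 of the 3 values shown sit). Compound 3 therefore has only a limit (> 50000 nM), and no number places it within the series.

Compound 4 (`COc1ccc(/C=C\c2cc(OC)c(OC)c(OC)c2)cc1OCc1ccc(CO)cc1`) carries hydroxy in place of (1-carboxy-2-hydroxypropyl)amino on a saturated chain carbon bound to an aromatic carbon. The measured changes at this place are a step that the two limits leave unreadable from compound 1 to compound 2 and a step that the two limits leave unreadable from compound 1 to compound 3 and a step that the two limits leave unreadable from compound 2 to compound 3 and none has a readable size. Within the data shown here, no measured compound carries hydroxy here, so these steps give no size for the change.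

With compound 3 at a limit (> 50000 nM), any number in this assay would lie towards stronger inhibition. The estimated step (an at least 3.3-fold lower number from compound 3 to compound 4 (0.52 log units; beyond the scatter)) is expected in that direction, although another limit remains possible. For compound 4 the expected value is 15000 nM with an estimated range (1500 nM to 50000 nM).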

Compound 4, half-maximal inhibitory concentration: > 50000 nM
Compound 4 gave a limit, no number; the forecaster's own chance of this, stated with the estimate: 40%; middle value at least 3.3-fold (0.52 log units) away from the limit.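

In this assay compound 4 gives > 50000 nM, a limit and not a number, so no step from compound 1, compound 2 or compound 3 to compound 4 can be read: the limit of > 50000 nM in this assay, at which 4 of the 4 values shown sit.

The compounds shown leave open whether any group at this place gives a number in this assay, and how large a change of group there would be.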